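From 4-chlorobenzyl to 2-bromobenzyl

This account rests on a few compounds, and the source may have more. Where it says the series, first, only, none or still open, it means among the compounds named here.

In a functional assay on HL-60 cells (Homo sapiens) for antiproliferative activity, with a stated time of 72 h (on this read-out lower numbers stand for stronger inhibition and higher numbers for weaker inhibition), compound 1 (`OC[C@H]1O[C@@H](n2cnc3c(NCc4ccc(F)cc4)ncnc32)[C@H](O)[C@@H]1O`) gives 1200 nM and compound 2 (`OC[C@H]1O[C@@H](n2cnc3c(NCc4ccc(Cl)cc4)ncnc32)[C@H](O)[C@@H]1O`) gives 1700 nM, so compound 2 stands level with compound 1 within the scatter. Compound 3 (`OC[C@H]1O[C@@H](n2cnc3c(NCc4ccccc4Br)ncnc32)[C@H](O)[C@@H]1O`) carries 2-bromophenyl in place of 4-chlorophenyl on a saturated chain carbon bound to a nitrogen on an aromatic ring. Within the data shown here, the only measured step, chloro in place of fluoro, is a 1.4-fold higher number from compound 1 to compound 2 (0.15 log units; within the scatter). Among the measured compounds shown here, no measured compound carries 2-bromophenyl, so that step bears only loosely. The expected change, a 1.1-fold lower number from compound 2 to compound 3 (0.05 log units; within the scatter), is none beyond the scatter. For compound 3 the estimate is 1500 nM, with an expected range of 600 nM to 4000 nM.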

Compound 3, half-maximal inhibitory concentration: 6600 nM
Compound 3: the middle estimate sits 4.4-fold (0.64 log units) below what was measured; the whole stated range lies below it.
By their numbers in this assay, from the lowest: compounds 1 and 2 (each within the scatter of the next); then compound 3.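

In this assay the aryl group on this saturated chain carbon proves able to move the read-out beyond the scatter: 2-bromophenyl in place of 4-chlorophenyl gives a 3.9-fold higher number from compound 2 to compound 3 (0.59 log units; beyond the scatter) and 2-bromophenyl in place of 4-fluorophenyl gives a 5.5-fold higher number from compound 1 to compound 3 (0.74 log units; beyond the scatter) while the step from fluoro to chloro had not left the scatter. Nothing measured here accounts for this loss. Compound 3 changes both the halogen and its printed ring number at once, so the shown compounds leave open whether the bromine or its placement carries the step. Going by these compounds, how 2-chlorophenyl or 4-bromophenyl would read remains open, and these two groups would separate the two changes.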